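Swapping the amide substituent on a stilbene-pyridine ether

The compounds below may be only part of what the source reports. "The series", "measured", "known", "first", "only" and "open" are said of these compounds alone.

Measured so far:
Compound 1 `O=C(Nc1ccccc1)c1cc(Oc2ccc(/C=C/c3ccccn3)cc2)ccn1`: 30200 nM
Compound 2 `O=C(c1cc(Oc2ccc(/C=C/c3ccccn3)cc2)ccn1)N1CCCC1`: 27000 nM
Compound 3 `O=C(Nc1ccccc1)c1cc(Oc2ccc(/C=C/c3ccncc3)cc2)ccn1`: > 100000 nM

These three compounds were tested in a functional assay on HepG2 cells (Homo sapiens) for antiproliferative activity, read by CCK-8 assay, with a stated time of 48 h; on this read-out lower numbers stand for stronger inhibition and higher numbers for weaker inhibition. Compound 1 gives 30200 nM in this assay, and compound 2 gives 27000 nM. For compound 3 the assay reports no number but a limit, > 100000 nM, so compound 3 stands at the weak end of what can be seen here (the limit of > 100000 nM in this assay, at which 1 of the 3 values shown sits).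

Compound 4 `COc1ccc(CNC(=O)c2cc(Oc3ccc(/C=C/c4ccncc4)cc3)ccn2)cc1` is not yet measured. It differs from compound 3 in one place: 4-methoxybenzyl in place of phenyl on an amide-type nitrogen.

Two measured steps offer guidance. The step of a 1.1-fold lower number from compound 1 to compound 2 (0.05 log units; within the scatter) changes the group on the amide, as the step to compound 4 does, and it stayed within the scatter. The step of an at least 3.3-fold higher number from compound 1 to compound 3 (0.51 log units; beyond the scatter) changed the pyridine and pushed the number to the limit; compound 4 keeps that pyridin-4-yl. The amide change is therefore expected to move the number little, and compound 4 is expected to stay near the limit as well, with the step of a number no higher from compound 3 to compound 4 (the limit leaves the size open) expected to lie within the scatter.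

The estimate for compound 4 is 100000 nM, ranging from 30000 nM to 300000 nM.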

Compound 4, half-maximal inhibitory concentration: > 100000 nM
Compound 4 gave a limit, no number (the forecaster's own chance of this, stated with the estimate: 60%); the middle value sits exactly at the limit.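

In this assay compound 4 gives > 100000 nM, which is a limit and not a number. Compound 3 also sits at a limit, so no step from compound 3 to compound 4 can be read: the limit of > 100000 nM in this assay, at which 2 of the 4 values shown sit.

The compounds shown leave open whether 4-methoxybenzyl in place of phenyl on an amide-type nitrogen changes activity at all when pyridin-4-yl is present.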